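Removing the Chloro Group from Compound 1

A few compounds are considered here, and "the series" means these few. Any claim that something is new, unique, unknown or untested is made for them only; others in the source may bear on it.

Compound 1 `O=C(O)CC[C@H]1CCc2cc(-c3cc(OC(F)(F)F)cc(Cl)c3F)ccc2O1`: 2200 nM
Compound 2 `Cc1cnc(Oc2cc(Cl)c(F)c(-c3ccc4c(c3)CC[C@H](CCC(=O)O)O4)c2)s1`: reported only as a limit, > 10000 nM

Among the compounds with values here, in a functional assay on HEK293 cells for agonist activity at Free fatty acid receptor 1 (Homo sapiens), read by HTRF and inositol phosphate accumulation, with a stated time of 60 min (a lower number here means that less compound is needed, a higher number that more compound is needed for the effect), compound 1 gives 2200 nM, the only number reported among the two measured compounds. Compound 2 gives only a limit in this assay, > 10000 nM. The step of an at least 4.5-fold higher number from compound 1 to compound 2 (0.65 log units; beyond the scatter) rests on (the limit of > 10000 nM in this assay, at which 1 of the 2 values shown sits).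

Compound 3 `O=C(O)CC[C@H]1CCc2cc(-c3cc(OC(F)(F)F)ccc3F)ccc2O1` differs from compound 1 by hydrogen in place of chloro on an aromatic carbon. Within the data shown here, no measured step covers this change; the only measured step concerns the trifluoromethoxy position, not the chloro group. For compound 3 a step within the scatter or a modest rise is expected, a 1.6-fold higher number from compound 1 to compound 3 (0.20 log units; within the scatter). Compound 3 is therefore estimated at 3500 nM, in the range 1200 nM to 10000 nM.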

Compound 3, half-maximal effective concentration: 2100 nM
The estimate for compound 3 lay 1.7-fold (0.22 log units) above the measured number; the range from low to high includes it.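

In this assay, hydrogen in place of chloro on this aromatic carbon, ortho to a fluoro group, gives a 1.0-fold lower number from compound 1 to compound 3 (0.02 log units; within the scatter), so compound 1 and compound 3 cannot be told apart. Within the data shown here, this is the first reading at the chloro position, as the earlier step concerned only the trifluoromethoxy position. Nothing given here bears on why the two compounds match.

As far as these compounds go, whether a methoxy group, a nitrile or an amine on this carbon would read the same remains open. So does whether the chloro-free compound 3 would respond differently to a change at the trifluoromethoxy position.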